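Replacing benzyl with 4-hydroxycyclohexyl on the aryl ether oxygen

The compounds below may be only part of what the source reports. "The series", "measured", "known", "first", "only" and "open" are said of these compounds alone.

Compound 1 `COc1cccc(NC(=S)NCCNS(=O)(=O)c2ccc(-c3ccccc3Oc3ccc([N+](=O)[O-])cc3)s2)c1` gives in a functional assay on HeLa cells (Homo sapiens) for inhibition, read by CCK-8 assay, with a stated time of 48 h (a lower number here means a stronger inhibitor, a higher number a weaker inhibitor), only a limit, > 50000 nM. Compound 2 `O=C(NCCNS(=O)(=O)c1ccc(-c2ccccc2Oc2ccc([N+](=O)[O-])c([N+](=O)[O-])c2)s1)Nc1cc(C(F)(F)F)cc(C(F)(F)F)c1` likewise gives only a limit in this assay, > 50000 nM. Within the data shown here, compound 3 `O=C(NCCNS(=O)(=O)c1ccc(-c2ccccc2OCc2ccccc2)s1)Nc1cc(C(F)(F)F)cc(C(F)(F)F)c1` is the one compound with a number, 13500 nM, and the step of an at least 3.7-fold lower number from compound 2 to compound 3 (0.56 log units; beyond the scatter) is the single measured step; it rests on (the limit of > 50000 nM in this assay, at which 2 of the 3 values shown sit). Compound 4 `O=C(NCCNS(=O)(=O)c1ccc(-c2ccccc2O[C@H]2CC[C@@H](O)CC2)s1)Nc1cc(C(F)(F)F)cc(C(F)(F)F)c1` differs from compound 3 by 4-hydroxycyclohexyl in place of benzyl on an oxygen on an aromatic ring. Among the measured compounds shown here, only the step from compound 2 to compound 3 concerns this oxygen, and it starts from a limit, so it says little about 4-hydroxycyclohexyl in place of benzyl. Compound 4 is expected to stay close to the number of compound 3, with an estimated 20000 nM within 5000 nM to 60000 nM. The expected step is a 1.5-fold higher number from compound 3 to compound 4 (0.17 log units; within the scatter), not beyond the scatter.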

Compound 4, half-maximal inhibitory concentration: 14100 nM
The estimate for compound 4 lay 1.4-fold (0.15 log units) above the measured number, and the stated range covers the measured number.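

In this assay, 4-hydroxycyclohexyl in place of benzyl on this oxygen gives a 1.0-fold higher number from compound 3 to compound 4 (0.02 log units; within the scatter), so an aromatic ring on the oxygen is not required for a number of this size, and a hydroxyl-bearing non-aromatic ring serves equally well. Against 3,4-dinitrophenyl, the same group gives an at least 3.5-fold lower number from compound 2 to compound 4 (0.54 log units; beyond the scatter), but the true size of this step stays unknown because it starts from a limit: the limit of > 50000 nM in this assay, at which 2 of the 4 values shown sit.

The compounds shown leave open whether plain cyclohexyl, or an amine in place of the hydroxyl, would shift the number. They also leave open whether any group on this oxygen can move it beyond the scatter.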